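The source may hold more compounds than are shown below. What is called first, only, known or untested is meant among the compounds shown, and "the series" means these compounds.

Of the compounds shown here, two built on a shared core have been tested in an assay on isolated protein for antagonist activity at transient receptor potential cation channel subfamily V member 1 (Homo sapiens); on this read-out higher numbers stand for weaker inhibition and lower numbers for stronger inhibition. Compound 1 `O=C(Nc1ccccc1Br)N1CCN(c2ccnc(Cl)n2)CC1` carries a 2-bromophenyl on an amide-type nitrogen, and in this assay compound 1 gives 1070 nM. Compound 2 `O=C(Nc1cccc(Br)c1)N1CCN(c2ccnc(Cl)n2)CC1` carries a 3-bromophenyl in that place, and in this assay compound 2 gives 1450 nM. Among the compounds with values here, the single measured step, a 1.4-fold higher number from compound 1 to compound 2 (0.13 log units; within the scatter), is small enough that the two compounds cannot be told apart. Compound 2 therefore holds the higher of the two numbers, but its gap to compound 1 lies within the scatter, so no order can be read from it.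

Compound 3 `O=C(Nc1ccccc1F)N1CCN(c2ccnc(Cl)n2)CC1` differs from compound 2 in one place: 2-fluorophenyl in place of 3-bromophenyl on an amide-type nitrogen. Only part of this change has a precedent. The step of a 1.4-fold higher number from compound 1 to compound 2 (0.13 log units; within the scatter) shows that the 2-bromophenyl and 3-bromophenyl compounds sit within the scatter of one another. Within the data shown here, no measured pair exchanges bromine for fluorine, so that part is untested. For compound 3 the expected step is a 1.0-fold higher number from compound 2 to compound 3 (0.01 log units; within the scatter), that is, none beyond the scatter. The estimate for compound 3 is 1500 nM, with a range from 500 nM to 4500 nM.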

Compound 3, half-maximal inhibitory concentration: 787 nM
Beside the measured number, compound 3's estimate is 1.9-fold (0.28 log units) above it; low and high end bracket the measured number.
By their numbers in this assay, from the lowest: compounds 3, 1 and 2 (each within the scatter of the next).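

The exchange of bromine for fluorine, untested until now, has a measured pair: in this assay, the step with the halogen on the 2-position of the phenyl is a 1.4-fold lower number from compound 1 to compound 3 (0.13 log units; within the scatter). Changing the halogen and its place together gives a 1.8-fold lower number from compound 2 to compound 3 (0.27 log units; within the scatter), so this wider change also fails to separate the compounds, and the 2-fluorophenyl, 2-bromophenyl and 3-bromophenyl groups on the amide-type nitrogen cannot be put in any order on these numbers. Nothing is available here that could explain why these compounds remain so close.

As far as these compounds go, what remains open is whether a group of another kind on this phenyl ring, such as a trifluoromethyl, a methoxy or an amine, would give a step beyond the scatter, or whether the insensitivity seen so far extends beyond these three halogen-bearing rings. Also open, from the compounds shown here alone, is what happens when the chlorine on the shared core is exchanged for an amine or a methoxy, since all three compounds carry that chlorine unchanged.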